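Swapping one group: from compound 3 to compound 4

The source may report more compounds than this note shows. Statements on the series, on what has been measured and on what is new or still open speak of the compounds shown alone.

Compound 1 (`O=c1nc(N2CCC(CCO)CC2)sc2c([N+](=O)[O-])cc(C(F)(F)F)cc12`): 91500 nM
Compound 2 (`O=c1nc(N2CC[C@](O)(COc3ccc(F)cc3)[C@@H](O)C2)sc2c([N+](=O)[O-])cc(C(F)(F)F)cc12`): 34300 nM
Compound 3 (`CC(=O)c1ccc(N2CCN(c3nc(=O)c4cc(C(F)(F)F)cc([N+](=O)[O-])c4s3)CC2)cc1`): > 105000 nM (a limit, not a number)

All three compounds were tested in a toxicity assay on HeLa cells (Homo sapiens) for cytotoxicity, read by colorimetric assay, with a stated time of 72 h; a lower number here means that less compound is tolerated, a higher number that more compound is tolerated. Compound 3 stands at > 105000 nM, and this is a limit of the assay rather than a number. Compound 4 (`O=c1nc(N2CCN(Cc3ccncc3)CC2)sc2c([N+](=O)[O-])cc(C(F)(F)F)cc12`) has not been measured yet. It carries (pyridin-4-yl)methyl in place of 4-acetylphenyl on an amine nitrogen in a ring. For the measured compounds named here, no measured pair of compounds differs in one place only, so no direct guide to this change exists.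

Going by the values given here, the expectation therefore rests on the only true numbers so far, from compound 1 at 91500 nM and compound 2 at 34300 nM. Both sit in the same high region as the limit, and a value for the new compound is expected there too. In this assay the expected step is small and towards a lower number, possibly no larger than the scatter: an at least 1.6-fold lower number from compound 3 to compound 4 (0.20 log units; that floor lies within the scatter). For compound 4 the estimated value is 65000 nM, with an expected range from 25000 nM to 110000 nM.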

Compound 4, half-maximal cytotoxic concentration: > 111000 nM
Compound 4: only a limit was reported; the forecaster's own chance of this, stated with the estimate: 35%; middle value at least 1.7-fold (0.23 log units) from the limit.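

In this assay compound 3 stands at > 105000 nM, which is a limit and not a number. Compound 4 stands at > 111000 nM, also a limit, so no step can be read from compound 3 to compound 4. The compounds shown leave open whether (pyridin-4-yl)methyl in place of 4-acetylphenyl changes the tolerated concentration at all, and by how much.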